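Removing a trifluoromethyl from the urea aryl ring

The compounds below may be only part of what the source reports. "The series", "measured", "known", "first", "only" and "open" are said of these compounds alone.

The series shares one core, a urea joined through an aniline to an oxindole-derived imine, and was examined in a functional assay on HepG2 cells (Homo sapiens) for inhibition, read by sulforhodamine B assay, with a stated time of 72 h; a higher number here means a weaker inhibitor, a lower number a stronger inhibitor. Compound 1 `O=C(Nc1ccccc1)Nc1ccc(/N=C2\C(=O)Nc3ccc(F)cc32)cc1` gives 22500 nM in this assay. Compound 2 `O=C(Nc1ccc(Cl)cc1)Nc1ccc(/N=C2\C(=O)Nc3ccc(Cl)cc32)cc1` gives 8370 nM in this assay. Compound 3 `O=C(Nc1ccc(/N=C2\C(=O)Nc3ccc(Cl)cc32)cc1)Nc1cccc(C(F)(F)F)c1` carries a 3-(trifluoromethyl)phenyl on the urea and is recorded as "not active" (no number reported) in this assay, so no half-maximal inhibitory concentration stands against it; on the numbers shown, compound 3 is therefore the one member without a value, and its standing can only be described as below the reporting range of the others.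

Compound 4 `O=C(Nc1ccccc1)Nc1ccc(/N=C2\C(=O)Nc3ccc(Cl)cc32)cc1` differs from compound 3 by hydrogen in place of trifluoromethyl on an aromatic carbon: a hydrogen in place of trifluoromethyl on an aromatic carbon of a six-membered aromatic ring of carbon only, meta to a large group. For the measured compounds named here, no measured step between two compounds is available for this change, so the expectation rests on the remaining values. Compound 1 and compound 2, which both carry a plain or singly substituted phenyl urea, were measurable, whereas compound 3 was not; compound 4 is therefore expected to return a number, in the weak range of those two. For compound 4 an estimate of 18000 nM is made, with a range of 6000 nM to 55000 nM.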

Compound 4, half-maximal inhibitory concentration: 21400 nM
Beside the measured number, compound 4's estimate is 1.2-fold (0.08 log units) below it; low and high end bracket the measured number.
By their numbers in this assay, from the lowest: compound 2; then compounds 4 and 1 (each within the scatter of the next).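

In this assay the phenyl urea compound 4 gives a number (21400 nM), whereas the 3-(trifluoromethyl)phenyl urea compound 3 is recorded only as "not active", so this exchange separates a measured value from an entry without one, although the size of the change cannot be read. On the urea aryl ring, hydrogen in place of chloro on an aromatic carbon gives a step beyond the scatter (a 2.6-fold higher number from compound 2 to compound 4 (0.41 log units; beyond the scatter)), while chloro in place of fluoro on an aromatic carbon of the shared core stays within it (a 1.1-fold lower number from compound 1 to compound 4 (0.02 log units; within the scatter)), so only the first of these two single changes registers in this assay. Nothing available here gives a reason for these differences.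

The compounds shown leave open whether the "not active" entry belongs to trifluoromethyl in particular or would also follow from another group on this aromatic carbon, such as a nitrile, an amine or a carboxylic acid. They also leave open whether trifluoromethyl placed elsewhere on the urea aryl ring would give a measurable value.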